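Changing the Benzyl Ring While the Amine Stays Fixed

The source may hold more compounds than are shown below. What is called first, only, known or untested is meant among the compounds shown, and "the series" means these compounds.

Compound 1 `c1ccc(COc2ccc(OCCOCCNc3ccncc3)cc2)cc1`, compound 2 `COc1ccc(COc2ccc(OCCOCCNC3CCCC3)cc2)cc1` and compound 3 `c1ccc(COc2ccc(OCCOCCNC3CCOC3)cc2)cc1` share one core and were tested in a functional assay on SK-OV-3 cells (Homo sapiens) for inhibition, read by CCK-8 assay, with a stated time of 70 h; on this read-out lower numbers stand for stronger inhibition and higher numbers for weaker inhibition. In this assay compound 2 gives 15700 nM, the lowest of the three numbers; compound 1 gives 20600 nM, within the scatter of it, while compound 3 gives 48000 nM, beyond the scatter. Among the measured compounds shown here, the only step measured so far, a 2.3-fold higher number from compound 1 to compound 3 (0.37 log units; beyond the scatter), concerns the group on the amine nitrogen. Compound 4 `O=C(O)c1cccc(COc2ccc(OCCOCCNC3CCCC3)cc2)c1` departs from compound 2 elsewhere: 3-carboxyphenyl in place of 4-methoxyphenyl on a saturated chain carbon bound to an oxygen on an aromatic ring. For the measured compounds named here, no measured step touches that part of the molecule, so none bears on this change, and the data give no direction for it. The expected change is therefore a 1.3-fold higher number from compound 2 to compound 4 (0.11 log units; within the scatter), held loosely. The estimate for compound 4 is 20000 nM, between 6000 nM and 70000 nM.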

Compound 4, half-maximal inhibitory concentration: > 100000 nM
Compound 4 was reported as a limit; the forecaster's own chance of this, stated with the estimate: 10%; middle value at least 5.0-fold (0.69 log units) from the limit.
By their numbers in this assay, from the lowest: compounds 2 and 1 (each within the scatter of the next); then compound 3. At a limit, above all of these: compound 4.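

In this assay compound 4 gives > 100000 nM, which is a limit of the assay and not a number. Among the compounds shown here, the one earlier step concerned only the group on the amine nitrogen, whereas 3-carboxyphenyl in place of 4-methoxyphenyl gives an at least 6.3-fold higher number from compound 2 to compound 4 (0.80 log units; beyond the scatter), so the read-out also responds to a change at this second part of the molecule. The full size of this step stays unknown, as it rests on one reading: the limit of > 100000 nM in this assay, at which 1 of the 4 values shown sits.

No step shown separates losing the methoxy group from gaining the carboxylic acid. On these data alone, it also stays open whether a methyl ester or a primary amide in place of that acid would give a measurable number in this assay.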